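The source may hold more compounds than are shown below. What is called first, only, known or untested is meant among the compounds shown, and "the series" means these compounds.

In a functional assay on MCF7 cells (Homo sapiens) for inhibition, read by resazurin assay, with a stated time of 24 h (on this read-out higher numbers stand for weaker inhibition and lower numbers for stronger inhibition), compound 3 `O=C1Nc2c(C(F)(F)F)cccc2C1(c1ccc(O)cc1)N1CCCCC1` gives > 1000000 nM. That value is a limit of the assay and not a number. Two relatives on the shared core do give numbers: compound 1 `O=C1Nc2c(C(F)(F)F)cccc2C1(c1ccc(O)cc1)c1ccc(OC(F)(F)F)cc1` gives 20 nM, and compound 2 `O=C1Nc2c(C(F)(F)F)cccc2C1(c1ccc(O)cc1)N1CCC(F)(F)CC1` gives 35 nM.

The next change replaces the piperidin-1-yl of compound 3, on a saturated ring carbon of a five-membered non-aromatic ring, to give compound 4 `CC1CN(C2(c3ccc(O)cc3)C(=O)Nc3c(C(F)(F)F)cccc32)CCC1(F)F`: a group of 9 heavy atoms (6 carbon, 1 nitrogen, 2 fluorine; one six-membered non-aromatic ring with 1 hetero atom) in place of a group of 6 heavy atoms (5 carbon, 1 nitrogen; one six-membered non-aromatic ring with 1 hetero atom), on a saturated ring carbon. The entering group keeps a six-membered non-aromatic ring with 1 hetero atom. It also holds fluorine, as the 4,4-difluoropiperidin-1-yl of compound 2 does, and carries more carbon than that group.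

Read in reverse, an at least 28000-fold higher number from compound 2 to compound 3 (4.45 log units; beyond the scatter) is the one measured step that bears on this change, and it is large. On that evidence, a similarly large move towards lower numbers, meaning stronger inhibition, is expected for compound 4 in this assay. For the measured compounds named here, no measured compound shows what the additional carbon does, so the range is kept wide. The estimated change is an at least 16000-fold lower number from compound 3 to compound 4 (4.22 log units; beyond the scatter). For compound 4 the estimated value is 60 nM, with an expected range from 15 nM to 400 nM.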

Compound 4, half-maximal inhibitory concentration: 70 nM
Beside the measured number, compound 4's estimate is 1.2-fold (0.07 log units) below it; low and high end bracket the measured number.
By their numbers in this assay, from the lowest: compounds 1, 2 and 4 (each within the scatter of the next, the first and the last beyond it). At a limit, above all of these: compound 3.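

In this assay, for the compounds shown here, the step of a 2.0-fold higher number from compound 2 to compound 4 (0.30 log units; within the scatter) shows that this position tolerates methyl in place of hydrogen on a saturated ring carbon of the fluorine-bearing piperidine ring, which answers what the earlier compounds could not say about the additional carbon. The second step, an at least 14000-fold lower number from compound 3 to compound 4 (4.15 log units; beyond the scatter), gives a second case, with a different entering group, in which a fluorine-bearing six-membered ring gives a measured number where the plain piperidin-1-yl of compound 3 does not, so the contrast no longer rests on compound 2 alone. The value of compound 3 remains a limit and not a number: the limit of > 1000000 nM in this assay, at which 1 of the 4 values shown sits.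

Both groups that give numbers here carry two fluorine atoms, so these compounds do not separate the effect of having one fluorine from that of having two, a question that a 4-fluoropiperidin-1-yl group could address. From the compounds shown here alone, it also stays open how a 4-methylpiperidin-1-yl group, with carbon but no fluorine, or a morpholin-4-yl group, with ring oxygen in place of the fluorine-bearing carbon, would read in this position.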